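Hydroxy versus methoxy in a urea-pyrazole series

The source may hold more compounds than are shown below. What is called first, only, known or untested is meant among the compounds shown, and "the series" means these compounds.

In a functional assay on TK-10 cells (Homo sapiens) for inhibition, read by sulforhodamine B assay, with a stated time of 48 h (a lower number here means a stronger inhibitor of growth, a higher number a weaker inhibitor of growth), the measured compounds stand as follows:
Compound 1 `O=C(Nc1cccc(-n2cc(-c3ccncc3)c(-c3ccc(Cl)c(O)c3)n2)c1)Nc1cccc(C(F)(F)F)c1` gives 2120 nM.
Compound 2 `COc1cc(-c2nn(-c3cccc(NC(=O)Nc4cc(C(F)(F)F)cc(C(F)(F)F)c4)c3)cc2-c2ccncc2)ccc1Cl` gives 894 nM.
Compound 3 `COc1cc(-c2nn(-c3cccc(NC(=O)Nc4cccc(C(F)(F)F)c4)c3)cc2-c2ccncc2)ccc1Cl` gives 1310 nM.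

Compound 2 shows the lowest number of the three, yet its gap to compound 3 lies within the scatter; only the gap to compound 1 is beyond it. The step to compound 3 is a 1.5-fold higher number from compound 2 to compound 3 (0.17 log units; within the scatter), so removing one trifluoromethyl changes little.

Compound 4 `O=C(Nc1cccc(-n2cc(-c3ccncc3)c(-c3ccc(Cl)c(O)c3)n2)c1)Nc1cc(C(F)(F)F)cc(C(F)(F)F)c1` keeps both trifluoromethyl groups of compound 2 and differs only as hydrogen in place of methyl on an oxygen on an aromatic ring. For the measured compounds named here, the one measured step that bears on this change is the reverse one, a 1.6-fold lower number from compound 1 to compound 3 (0.21 log units; within the scatter), which stayed within the scatter. Read backwards, it points to a slightly higher number for compound 4 in this assay , but nothing beyond the scatter.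

Compound 4 is therefore expected to give 1300 nM, within 600 nM to 3000 nM, which means an estimated step of a 1.5-fold higher number from compound 2 to compound 4 (0.16 log units; within the scatter).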

Compound 4, concentration for 50% growth inhibition: 959 nM
Compound 4: middle estimate off by 1.4-fold (0.13 log units), on the high side; low and high end bracket the measured number.
By their numbers in this assay, from the lowest: compounds 2, 4, 3 and 1 (each within the scatter of the next, the first and the last beyond it).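

Methoxy to hydroxy on the 4-chloro-3-methoxyphenyl group can now be read on a second core, and in this assay it again stays within the scatter, with a 1.1-fold higher number from compound 2 to compound 4 (0.03 log units; within the scatter). The two readings of this change agree: the same change on two cores in this assay, a 1.6-fold lower number (0.21 log units; within the scatter) from compound 1 to compound 3 and a 1.1-fold lower number (0.03 log units; within the scatter) from compound 4 to compound 2, 1.5-fold (0.18 log units) apart, within the scatter of two such steps. The trifluoromethyl change can now be read on the hydroxy core too, where a 2.2-fold lower number from compound 1 to compound 4 (0.34 log units; beyond the scatter) gives a step beyond the scatter, and it does not separate from the step on the methoxy core: the same change on two cores in this assay, a 1.5-fold higher number (0.17 log units; within the scatter) from compound 2 to compound 3 and a 2.2-fold higher number (0.34 log units; beyond the scatter) from compound 4 to compound 1, 1.5-fold (0.18 log units) apart, within the scatter of two such steps.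

The compounds shown leave open how a longer chain such as ethoxy, or an amine in place of the methoxy group, would read in this assay. They also leave open whether any change at this position can move the number beyond the scatter.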